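A few compounds are considered here, and "the series" means these few. Any claim that something is new, unique, unknown or untested is made for them only; others in the source may bear on it.

Compound 1 `Cc1cnc(OC[C@@]2(c3ccccc3)C[C@H]2C(=O)Nc2ccc(C#N)cn2)c(C)n1` is the only one of the three measured compounds that yields a number in an assay on isolated protein for binding affinity to Orexin/Hypocretin receptor type 1 (Homo sapiens), read by radioligand binding (a higher number here means a weaker inhibitor, a lower number a stronger inhibitor), where compound 1 gives 73 nM. Compound 2 `Cc1nn(C)cc1OCC1(c2ccccc2)CC1C(=O)Nc1ccc(C#N)cn1` returns only a limit of the assay in this assay, > 2000 nM. Compound 3 `CCn1cc(OC[C@]2(c3ccccc3)C[C@@H]2C(=O)Nc2ccc(C#N)cn2)c(C)n1` likewise returns only a limit in this assay, > 2000 nM, so it stands at the limit of > 2000 nM in this assay, at which 2 of the 3 values shown sit, rather than at a measured point. Compound 4 `CCn1cc(OCC2(c3ccccc3)CC2C(=O)Nc2ccc(C#N)cn2)c(C)n1` differs from compound 3 only in how the stereocentres are drawn: the two compounds have the same atoms and bonds; at least one stereo element is drawn with a configuration in one of them and without one in the other: 2 of 2 stereo elements differ; a stereocentre at a saturated ring carbon is drawn R in compound 3 and without a configuration in compound 4; a stereocentre at a saturated ring carbon is drawn S in compound 3 and without a configuration in compound 4. Given the same atoms and bonds, the step of a number no higher from compound 3 to compound 4 (the limit leaves the size open) is expected to be small. Compound 4 is therefore estimated at 2000 nM, within 400 nM to 6000 nM, with a fair chance that only a limit is again reported.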

Compound 4, inhibition constant: 391 nM
The estimate for compound 4 lay 5.1-fold (0.71 log units) above the measured number, outside the stated range (below it).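

In this assay, stereo drawing alone now separates two compounds with the same atoms and bonds, giving an at least 5.1-fold lower number from compound 3 to compound 4 (0.70 log units; beyond the scatter), and the comparison rests on one point: the fact that one of compounds 3 and 4 is drawn with a defined configuration and the other without, at the place where they differ. With no configuration drawn on either side, methyl in place of hydrogen on a saturated chain carbon bound to an aromatic nitrogen gives an at least 5.1-fold lower number from compound 2 to compound 4 (0.70 log units; beyond the scatter). Both steps start from a limit rather than a number, which leaves their full size open: the limit of > 2000 nM in this assay, at which 2 of the 4 values shown sit.

The compounds shown leave open which configuration accounts for the number seen for compound 4. They also leave open how a longer chain, such as propyl, would read on that aromatic nitrogen.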